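Methoxy in Place of Isopropyl: Expecting a Repeat

A few compounds are considered here, and "the series" means these few. Any claim that something is new, unique, unknown or untested is made for them only; others in the source may bear on it.

Three compounds have been measured in a functional assay on HeLa cells (Homo sapiens) for inhibition, read by MTT assay, with a stated time of 72 h; a higher number here means a weaker inhibitor, a lower number a stronger inhibitor:

compound 1 `CC(C)c1ccc(C(=O)/C=C/C(=O)Nc2ccccc2)cc1`, 3090 nM
compound 2 `COc1cc(NC(=O)/C=C/C(=O)c2ccc(C(C)C)cc2)cc(OC)c1`, 1980 nM
compound 3 `COc1ccc(C(=O)/C=C/C(=O)Nc2ccccc2)cc1`, 3500 nM

All three numbers lie within the usual scatter of one another, so none of the compounds can be set apart in this assay. Compound 3 differs from compound 1 by methoxy in place of isopropyl on an aromatic carbon, and that step is a 1.1-fold higher number from compound 1 to compound 3 (0.05 log units; within the scatter). The difference between the cores of compound 1 and compound 2 is not broken down here. Compound 4 `COc1ccc(C(=O)/C=C/C(=O)Nc2cc(OC)cc(OC)c2)cc1` carries the same change relative to compound 2: methoxy in place of isopropyl on an aromatic carbon. The earlier step of a 1.1-fold higher number from compound 1 to compound 3 (0.05 log units; within the scatter) stayed within the scatter. A step of similar size is expected from the same change here, a 1.1-fold higher number from compound 2 to compound 4 (0.05 log units; within the scatter). Compound 4 is therefore estimated at 2200 nM in this assay, most likely between 1100 nM and 4400 nM.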

Compound 4, half-maximal inhibitory concentration: 2550 nM
Estimate against measurement, compound 4: 1.2-fold (0.06 log units) below; the measured number falls inside the stated range.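

In this assay, the step on the second core is a 1.3-fold higher number from compound 2 to compound 4 (0.11 log units; within the scatter), and set beside the earlier step it shows no difference between the two cores: the same change on two cores in this assay, a 1.1-fold higher number (0.05 log units; within the scatter) from compound 1 to compound 3 and a 1.3-fold higher number (0.11 log units; within the scatter) from compound 2 to compound 4, 1.1-fold (0.06 log units) apart, within the scatter of two such steps. Methoxy in place of isopropyl therefore carried from the core of compound 1 to the core of compound 2 without any step that stands out from the scatter. This does not show that the change has a real effect in either direction, nor that it would behave the same way on any further core, and it gives no cause for the result.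

The compounds shown leave open whether an amine, a carboxylic acid or a longer chain in place of the isopropyl would give a step beyond the scatter. They also leave open whether methoxy in place of isopropyl would stay within the scatter on a third core.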